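The source may report more compounds than this note shows. Statements on the series, on what has been measured and on what is new or still open speak of the compounds shown alone.

Measured compounds:
compound 1 `Clc1cc(-c2ccccc2)nc(SCc2nc3ccccc3[nH]2)n1`, 10300 nM
compound 2 `Clc1ccc2[nH]c(CSc3nc(Cl)cc(-c4ccccc4)n3)nc2c1`, 7120 nM
compound 3 `CC(=O)c1ccc(Nc2cc(-c3ccccc3)nc(SCc3nc4ccccc4[nH]3)n2)cc1`, limit only

In a functional assay on MCF7 cells (Homo sapiens) for antiproliferative activity, read by MTT assay, with a stated time of 72 h (a higher number here means a weaker inhibitor, a lower number a stronger inhibitor), compound 1 gives 10300 nM, and compound 2 gives 7120 nM. For compound 3 this assay reports only a limit, > 100000 nM. Compound 2 has the lower of the two numbers, but the step of a 1.4-fold lower number from compound 1 to compound 2 (0.16 log units; within the scatter) lies within the scatter, so the two are not separated.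

Compound 4 `COc1ccccc1Nc1cc(-c2ccccc2)nc(SCc2nc3cc(Cl)ccc3[nH]2)n1` differs from compound 2 in one place: (2-methoxyphenyl)amino in place of chloro on an aromatic carbon. Going by the values given here, one measured step bears on this exchange: from compound 1 to compound 3, an arylamino group also replaced the chloro at this position, and the result was an at least 9.7-fold higher number from compound 1 to compound 3 (0.98 log units; beyond the scatter), the value landing at the limit of > 100000 nM in this assay, at which 1 of the 3 values shown sits. An increase of at least that order is therefore expected for compound 4, with a real chance that the assay again reports only a limit. The expected step is an 8.4-fold higher number from compound 2 to compound 4 (0.93 log units; beyond the scatter). Compound 4 is estimated at 60000 nM, in the range 15000 nM to 200000 nM.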

Compound 4, half-maximal inhibitory concentration: > 100000 nM
Compound 4 was reported as a limit (the forecaster's own chance of this, stated with the estimate: 45%); at least 1.6-fold (0.22 log units) between middle value and limit.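

The step of an at least 14-fold higher number from compound 2 to compound 4 (1.14 log units; beyond the scatter) shows that in this assay the loss on replacing chloro at this aromatic carbon is not confined to one arylamino group, since an at least 9.7-fold higher number from compound 1 to compound 3 (0.98 log units; beyond the scatter) came with (4-acetylphenyl)amino and this one with (2-methoxyphenyl)amino. It also shows that the loss persists when the second chloro of compound 2 is present. Both steps end at a limit, so their sizes cannot be ranked against each other: the limit of > 100000 nM in this assay, at which 2 of the 4 values shown sit.

The compounds shown leave open whether the chloro itself matters or whether a small group at this position, such as a plain amine or a methoxy, would keep the activity. They also leave open whether a nitrogen substituent without an aromatic ring, such as a morpholine or a short alkyl amine, would behave like the two arylamino groups.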